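The compounds below may be only part of what the source reports. "The series", "measured", "known", "first", "only" and "open" are said of these compounds alone.

Measured so far:
- compound 1, `CCCNC(=C\C(=O)/C=C/c1ccc(O)c(OC)c1)/C=C/c1ccc(O)c(OC)c1`: 97%
- compound 2, `C=CCNC(=C\C(=O)/C=C/c1ccc(O)c(OC)c1)/C=C/c1ccc(O)c(OC)c1`: 89%
- compound 3, `CC(=O)Oc1ccc(/C=C/C(=O)/C=C(/C=C/c2ccc(OC(C)=O)cc2)NCC(C)C)cc1`: 102%

All three were tested in a functional assay on Caco-2 cells (Homo sapiens), read by fluorescence, tested at 1 uM; on this read-out higher numbers stand for a weaker effect at the one concentration tested and lower numbers for a stronger effect. Compound 2 gives the smallest of the three values, though its distance from compound 1 lies within the usual scatter; only the distance to compound 3 lies beyond it. Compound 4, `COc1cc(/C=C/C(=O)/C=C(/C=C/c2ccc(O)c(OC)c2)NCC(C)C)ccc1O`, differs from compound 2 in one place: isopropyl in place of vinyl on a saturated chain carbon bound to an amine nitrogen. Among the compounds with values here, the only measured step that bears on this change is the one at the same place, a number 8 percentage points lower from compound 1 to compound 2 (within the scatter), which stayed within the scatter. Changing the group on that chain carbon has therefore not produced a step beyond the scatter so far, and none is expected here either. Compound 4 is expected to give about 93% in this assay, between 80% and 106%, a step of a number 4 percentage points higher from compound 2 to compound 4 (within the scatter).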

Compound 4, a percentage reported as activity, at one concentration (the size of the read-out at that concentration, not a potency): 91%
Beside the measured number, compound 4's estimate is 2 percentage points above it, within the range that was stated.
By their numbers in this assay, from the lowest: compounds 2, 4, 1 and 3 (each within the scatter of the next, the first and the last beyond it).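

In this assay, the two new steps, a number 2 percentage points higher from compound 2 to compound 4 (within the scatter) and a number 6 percentage points lower from compound 1 to compound 4 (within the scatter), show that a branched chain behaves like the straight propyl and allyl chains at this place. Replacing vinyl with isopropyl, or adding a methyl branch to the saturated chain, therefore gives no step beyond the scatter. Nothing available gives a reason for this result.

The compounds shown leave open whether a much longer chain, or a chain ending in an amine or a carboxylic acid, would give a larger step at this place.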